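Three Ring Substituents Tried, a Hexylsulfanyl Chain Follows

The source may report more compounds than this note shows. Statements on the series, on what has been measured and on what is new or still open speak of the compounds shown alone.

Three amides built on one shared core have been measured in an assay on cells for antagonist activity at transient receptor potential cation channel subfamily V member 1 (Homo sapiens), read by FLIPR and calcium flux, with a stated time of 6 min; a lower number here means a stronger inhibitor, a higher number a weaker inhibitor. Compound 1 `CC(C(=O)NCc1ccc(C(C)(C)C)nc1N1CCCC1)c1ccc(NS(C)(=O)=O)c(F)c1` gives 1.2 nM, compound 2 `CC(C(=O)NCc1ccc(C(C)(C)C)nc1N1CCCCCC1)c1ccc(NS(C)(=O)=O)c(F)c1` gives 0.9 nM, and compound 3 `CC(C(=O)NCc1ccc(C(C)(C)C)nc1OCc1ccc(F)cc1)c1ccc(NS(C)(=O)=O)c(F)c1` gives 0.8 nM. Compound 3 stands nearest to compound 2, with a 1.1-fold lower number from compound 2 to compound 3 (0.05 log units; within the scatter), and furthest from compound 1, with a 1.5-fold lower number from compound 1 to compound 3 (0.18 log units; within the scatter); the remaining step, a 1.3-fold lower number from compound 1 to compound 2 (0.12 log units; within the scatter), likewise stays within the scatter. Compound 4 `CCCCCCSc1nc(C(C)(C)C)ccc1CNC(=O)C(C)c1ccc(NS(C)(=O)=O)c(F)c1` differs from compound 3 only by hexylsulfanyl in place of (4-fluorobenzyl)oxy on an aromatic carbon. All three measured steps exchanged the group at this same aromatic carbon, and none of them moved the number beyond the scatter, so the step of a 1.3-fold higher number from compound 3 to compound 4 (0.10 log units; within the scatter) is expected to be small as well, with no clear direction. Compound 4 is therefore estimated at 1 nM, with a range from 0.3 nM to 3.5 nM.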

Compound 4, inhibition constant: 1.5 nM
Estimate against measurement, compound 4: 1.5-fold (0.18 log units) below; the measured number falls inside the stated range.
By their numbers in this assay, from the lowest: compounds 3, 2, 1 and 4 (each within the scatter of the next).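

All three earlier groups at this aromatic carbon held a ring, whereas hexylsulfanyl has no ring and brings in sulfur, yet in this assay every step to the open chain stays within the scatter (a 1.9-fold higher number from compound 3 to compound 4 (0.27 log units; within the scatter); a 1.7-fold higher number from compound 2 to compound 4 (0.22 log units; within the scatter); a 1.3-fold higher number from compound 1 to compound 4 (0.10 log units; within the scatter)). Among these compounds, then, a ring in this group is not required for a number of this size. No measurement at hand gives a cause for this.

The compounds shown leave open whether the sulfur or the chain carries this result. They also leave open whether a hexyloxy chain, a shorter butylsulfanyl chain or a carboxylic acid at this carbon would keep the number in this range.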